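A few compounds are considered here, and "the series" means these few. Any claim that something is new, unique, unknown or untested is made for them only; others in the source may bear on it.

Measured compounds:
Compound 1, `COc1ccc(-n2c(Nc3nc(-c4ccc([N+](=O)[O-])cc4)cs3)n[nH]c2=S)cc1` — in a functional assay on the whole organism (strain Swiss albino) for inhibition, with Mus musculus as the target, with a stated time of 4 h (on this read-out higher numbers stand for an effect only at larger amounts of compound and lower numbers for an effect already at smaller amounts), compound 1 gives 300 mg/kg.
Compound 2, `COc1ccccc1-n1c(Nc2nc(-c3ccccc3)cs2)n[nH]c1=S` — in this assay compound 2 gives 300 mg/kg.
Compound 3, `COc1ccc(-n2c(Nc3nc(-c4ccccc4)cs3)n[nH]c2=S)cc1` — in this assay compound 3 gives 100 mg/kg.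

Compound 3 holds the lowest number of the three in this assay; compound 1 and compound 2 both sit higher than it by steps beyond the scatter, the one on a 3.0-fold lower number from compound 1 to compound 3 (0.48 log units; beyond the scatter), the other on a 3.0-fold lower number from compound 2 to compound 3 (0.48 log units; beyond the scatter). Compound 3 is therefore the reference point of the series as it stands.

Compound 4, `COc1ccc(-n2c(Nc3nc(-c4ccc(Cl)cc4)cs3)n[nH]c2=S)cc1`, is not yet measured. It differs from compound 3 by chloro in place of hydrogen on an aromatic carbon.

Among the compounds with values here, of the measured steps, only the one from compound 1 to compound 3 touches the same aromatic carbon: there, a 3.0-fold lower number from compound 1 to compound 3 (0.48 log units; beyond the scatter) was seen for hydrogen in place of nitro. The step from compound 2 to compound 3 concerns the methoxyphenyl on the aromatic nitrogen and does not bear on the present change. Within the data shown here, no measured pair shows chloro in place of hydrogen anywhere, so the direction for compound 4 in this assay is open; a substituent at this carbon has so far only pushed the number up, but a single pair is thin ground.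

The expectation for compound 4 is therefore a step of a 1.5-fold higher number from compound 3 to compound 4 (0.18 log units; within the scatter), likely within or near the scatter, and compound 4 is estimated at 150 mg/kg, with a range from 60 mg/kg to 350 mg/kg.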

Compound 4, minimum effective dose: 100 mg/kg
Beside the measured number, compound 4's estimate is 1.5-fold (0.18 log units) above it; the range from low to high includes it.
By their numbers in this assay, from the lowest: compounds 3 and 4 (each within the scatter of the next); then compounds 1 and 2 (each within the scatter of the next).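

In this assay, chloro in place of hydrogen on this aromatic carbon, para to a large group, gives no change at the digits printed from compound 3 to compound 4 (within the scatter) and so shows that a substituent here need not raise the number, a possibility the nitro pair alone had left standing. Chloro in place of nitro at the same carbon gives a 3.0-fold lower number from compound 1 to compound 4 (0.48 log units; beyond the scatter) and matches in size the step seen for hydrogen in place of nitro, so among hydrogen, chloro and nitro at this carbon, only nitro in compound 1 stands apart from the other two. Nothing at hand gives a measured basis for the gap between nitro and chloro here.

Whether this tolerance extends to other kinds of substituent is open: an amine or a carboxylic acid at this carbon could read either way in this series. Also open, going by these compounds, is whether 2-methoxyphenyl in place of 4-methoxyphenyl on the aromatic nitrogen would raise the number with 4-chlorophenyl as it does with phenyl.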